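The compounds below may be only part of what the source reports. "The series", "measured", "known", "first", "only" and "open" are said of these compounds alone.

Compound 1 `COc1cc(C2=NN(C(C)=O)C(c3ccc([N+](=O)[O-])cc3)C2)cc(OC)c1OC`: 51000 nM
Compound 2 `COc1ccc(OC)c(C2CC(c3cc(OC)c(OC)c(OC)c3)=NN2C(C)=O)c1`: > 100000 nM

Both values come from a functional assay on B16 cells (Mus musculus) for cytotoxicity, read by MTT assay, with a stated time of 72 h; on this read-out higher numbers stand for weaker inhibition and lower numbers for stronger inhibition. Compound 2 gives > 100000 nM, which is a limit of the assay and not a number, so it stands at the limit of > 100000 nM in this assay, at which 1 of the 2 values shown sits.

Compound 3 `COc1ccc(C2CC(c3cc(OC)c(OC)c(OC)c3)=NN2C(C)=O)cc1O` has not been measured. It carries 3-hydroxy-4-methoxyphenyl in place of 2,5-dimethoxyphenyl on a saturated ring carbon.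

Within the data shown here, only one measured step swaps a group at this same place: an at least 1.9-fold higher number from compound 1 to compound 2 (0.29 log units; that floor lies within the scatter). Its floor lies within the scatter, so it fixes no clear size. Compound 1, at 51000 nM, does show that the shared core can give a readable number in this assay. A modest move toward a lower number is therefore expected, though compound 3 could also stay at the limit. The expected change is an at least 2.0-fold lower number from compound 2 to compound 3 (0.30 log units; that floor lies within the scatter). For compound 3 the estimated value is 50000 nM, with an expected range of 12000 nM to 100000 nM.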

Compound 3, half-maximal inhibitory concentration: > 100000 nM
Compound 3 was reported as a limit; the forecaster's own chance of this, stated with the estimate: 35%; middle value at least 2.0-fold (0.30 log units) from the limit.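

In this assay compound 3 gives > 100000 nM, which is a limit and not a number, so a second oxygen-bearing phenyl group at this place, now with a hydrogen-bond donor, also gives no readable value. The step between compound 2 and compound 3 cannot be read, since both sit at the limit: the limit of > 100000 nM in this assay, at which 2 of the 3 values shown sit. Replacing 4-nitrophenyl with 3-hydroxy-4-methoxyphenyl gives an at least 1.9-fold higher number from compound 1 to compound 3 (0.29 log units; that floor lies within the scatter), so this change, like the earlier one, fixes no clear size.

Going by these compounds, how compound 2 and compound 3 rank against each other stays open, as does how far either lies from the limit. Also open, on these data alone, is whether a phenyl group carrying an amine or a carboxylic acid on this saturated ring carbon would give a readable number.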